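Shifting a Bromine: From Compound 1 to Compound 4

The source may report more compounds than this note shows. Statements on the series, on what has been measured and on what is new or still open speak of the compounds shown alone.

Three related compounds were tested for their ability to kill colon cancer cells in a functional assay on SW480 cells (Homo sapiens) for cytotoxicity, read by sulforhodamine B assay, with a stated time of 48 h; a higher number here means a weaker inhibitor, a lower number a stronger inhibitor. Compound 1 `O=C(/C=C/c1cccc(Br)c1)c1cccc(-c2cccc(F)c2)c1` gives 8610 nM in this assay. Compound 3 `COc1cccc(/C=C/C(=O)c2ccc(N)c(-c3ccc(F)cc3)c2)c1OC` gives 12500 nM in this assay. Compound 2 `COc1ccc(/C=C/C(=O)c2cccc(Br)c2)cc1` gives "not determined" (no result reported) in this assay, so no result is available for it. Compound 1 therefore has the lower of the two numbers, but its distance from compound 3 falls inside the ordinary scatter of repeated measurements, so the two cannot be told apart with confidence.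

Compound 4 `O=C(/C=C/c1ccc(Br)cc1)c1cccc(-c2cccc(F)c2)c1` has the same atoms as compound 1, joined differently: 4-bromophenyl in place of 3-bromophenyl on a double-bonded chain carbon bound to a double-bonded chain carbon. Within the data shown here, no measured pair here shows a bromine moved in this way, so there is nothing to anchor a prediction of direction. With the rest of the molecule unchanged and only the bromine relocated on that ring, the step of a 1.0-fold lower number from compound 1 to compound 4 (0.01 log units; within the scatter) from compound 1 to compound 4 is expected to be none beyond the scatter. Compound 4 is estimated at 8500 nM, with a plausible range from 3000 nM to 25000 nM.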

Compound 4, half-maximal inhibitory concentration: 18200 nM
For compound 4 the middle estimate is 2.1-fold (0.33 log units) below the measured one; low and high end bracket the measured number.
By their numbers in this assay, from the lowest: compounds 1, 3 and 4 (each within the scatter of the next, the first and the last beyond it).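

Putting 4-bromophenyl in place of 3-bromophenyl on the double-bonded chain carbon gives a 2.1-fold higher number from compound 1 to compound 4 (0.33 log units; beyond the scatter) in this assay. This is the first pair shown that differs in one place only, so it is the first to show that relocating the bromine on this ring, with the same atoms throughout, can shift the result by a modest but real amount, with the higher number meaning a weaker inhibitor. No measurement available here accounts for this shift.

From the compounds shown here alone, the pair compares only two placements of one bromine on one shared core, so it remains open whether the same shift would appear on a different core. Going by these compounds, it also remains open how a ring carrying a nitrile or a carboxylic acid instead of bromine would behave at this chain carbon.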